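Trifluoromethyl to fluoro on the benzyl ring: cytotoxicity outlook

The source may report more compounds than this note shows. Statements on the series, on what has been measured and on what is new or still open speak of the compounds shown alone.

Compound 1, `CCOC(=O)c1cnc(N2CCN(Cc3ccccc3C#N)CC2)nc1Oc1c(C)cc(-c2ccc(C#N)cc2)cc1C`, gives > 125000 nM in an ADME assay on MT4 cells (Homo sapiens) for cytotoxicity, read by MTT assay, with a stated time of 4 days; on this read-out higher numbers stand for lower toxicity in this test and lower numbers for higher toxicity in this test.
Compound 2, `CCOC(=O)c1cnc(N2CCN(Cc3ccccc3C(F)(F)F)CC2)nc1Oc1c(C)cc(-c2ccc(C#N)cc2)cc1C`, gives > 125000 nM in this assay.

Both of these values are limits of the assay, not numbers. Compound 2 therefore stands at the limit, with no reading of its own. Among the measured compounds shown here, the only measured step, a step that the two limits leave unreadable from compound 1 to compound 2, cannot be sized for the same reason, since both ends of it rest at the limit of > 125000 nM in this assay, at which 2 of the 2 values shown sit.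

Compound 3, `CCOC(=O)c1cnc(N2CCN(Cc3ccccc3F)CC2)nc1Oc1c(C)cc(-c2ccc(C#N)cc2)cc1C`, is not yet measured. It differs from compound 2 in one place: fluoro in place of trifluoromethyl on an aromatic carbon. This is a small change in a part of the molecule well away from the shared core.

For the measured compounds named here, no measured step gives a readable size, so there is nothing to point to a shift in either direction. The working expectation is that compound 3 behaves like compound 2 and sits at the same limit, so the expected step is a step that the limit leaves unreadable from compound 2 to compound 3, with no change beyond the scatter. The estimate for compound 3 in this assay is 150000 nM, ranging from 60000 nM to 400000 nM.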

Compound 3, half-maximal cytotoxic concentration: > 125000 nM
Compound 3 was reported as a limit; the forecaster's own chance of this, stated with the estimate: 85%; the middle value is on the limit's open side.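

Compound 1, compound 2 and compound 3 all give only a limit of the assay in this assay, not a number, so no step among them can be read: the limit of > 125000 nM in this assay, at which 3 of the 3 values shown sit.

As far as these compounds go, what stays open is where the true cytotoxic concentration of each compound lies, and whether cyano, trifluoromethyl and fluoro on the benzyl ring differ at all in this assay.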